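The source may report more compounds than this note shows. Statements on the series, on what has been measured and on what is new or still open speak of the compounds shown alone.

Measured in an ADME assay on microsomes from liver (Homo sapiens) for metabolic stability; a higher number here means faster removal of the compound, a lower number slower removal:
- Compound 1 `Cc1ccc([C@H](C)NC(=O)Cn2nnc3ccccc3c2=O)nc1`: < 9.9 mL/min/kg (a limit)
- Compound 2 `Cc1ccc([C@H](C)NC(=O)Cn2nnc3ccccc3c2=O)c(F)c1`: 28 mL/min/kg
- Compound 3 `C[C@H](NC(=O)Cn1nnc2ccccc2c1=O)c1ccc(C(F)(F)F)cc1F`: 17 mL/min/kg

Compound 3 stands at 17 mL/min/kg, and the step separating it from compound 2 does not leave the scatter: a 1.6-fold lower number from compound 2 to compound 3 (0.22 log units; within the scatter). The reading for compound 1 is a limit, so compound 3 has no exact comparison there.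

Compound 4 `C[C@H](NC(=O)Cn1nnc2ccccc2c1=O)c1ccc(OC(F)(F)F)cc1F` carries one change from compound 3: trifluoromethoxy in place of trifluoromethyl on an aromatic carbon. This puts trifluoromethoxy in place of trifluoromethyl on an aromatic carbon, para to a large group. Among the measured compounds shown here, the exchange from compound 2 to compound 3 is the only measured step on this same carbon, so it bears most directly. The larger at least 2.8-fold higher number from compound 1 to compound 2 (0.45 log units; beyond the scatter) replaced the ring itself and bears less.

As far as these compounds go, no step beyond the scatter is therefore expected in this assay, and the direction remains open. The expected change is a 1.2-fold higher number from compound 3 to compound 4 (0.07 log units; within the scatter). For compound 4 the estimated value is 20 mL/min/kg, with an expected range of 10 mL/min/kg to 40 mL/min/kg.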

Compound 4, clearance: < 9.9 mL/min/kg
Compound 4 was reported as a limit (the forecaster's own chance of this, stated with the estimate: 10%); middle value at least 2.0-fold (0.30 log units) from the limit.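

In this assay compound 4 gives < 9.9 mL/min/kg, which is a limit: the limit of < 9.9 mL/min/kg in this assay, at which 2 of the 4 values shown sit. On this aromatic carbon, para to a large group, trifluoromethoxy in place of trifluoromethyl gives an at least 1.7-fold lower number from compound 3 to compound 4 (0.23 log units; that floor lies within the scatter), and the true size of this exchange remains unfixed. Measured against methyl, the same carbon now yields a step that clears the scatter, an at least 2.8-fold lower number from compound 2 to compound 4 (0.45 log units; beyond the scatter), whereas the earlier exchange on this carbon, a 1.6-fold lower number from compound 2 to compound 3 (0.22 log units; within the scatter), did not.

As far as these compounds go, how far trifluoromethoxy truly separates from trifluoromethyl remains open, with only a limit on one side of the pair. Also open, from the compounds shown here alone, is how a methoxy group, a chlorine atom or a nitrile would read on this aromatic carbon, and whether any of them would stand apart from trifluoromethoxy.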